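Notes on oxygen substituents of a shared core

This account rests on a few compounds, and the source may have more. Where it says the series, first, only, none or still open, it means among the compounds named here.

Measured in a functional assay on HeLa cells (Homo sapiens) for cytotoxicity; on this read-out higher numbers stand for weaker inhibition and lower numbers for stronger inhibition:
- compound 1 `CCCOC1=CC(=O)c2ccccc2C1=O`: 51600 nM
- compound 2 `C/C=C/C(=O)OC1=CC(=O)c2ccccc2C1=O`: 37900 nM

Within the data shown here, compound 2 stands level with compound 1 within the scatter, and these are the only two numbers so far. Compound 3 `CCCCOC1=CC(=O)c2ccccc2C1=O` has not yet been measured. The change is butyl in place of (prop-1-en-1-yl)carbonyl on an oxygen on an unsaturated carbon.

Among the measured compounds shown here, only one measured step bears on this place: a 1.4-fold lower number from compound 1 to compound 2 (0.13 log units; within the scatter), which exchanged propyl for (prop-1-en-1-yl)carbonyl. For the measured compounds named here, no measured compound carries butyl, so this is a thin basis. With that single step as the guide, no move beyond the scatter is expected in this assay. The estimated step is a 1.1-fold higher number from compound 2 to compound 3 (0.04 log units; within the scatter). For compound 3 the expected value is 42000 nM, with an estimated range of 20000 nM to 85000 nM.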

Compound 3, half-maximal inhibitory concentration: 35300 nM
Beside the measured number, compound 3's estimate is 1.2-fold (0.08 log units) above it; low and high end bracket the measured number.
By their numbers in this assay, from the lowest: compounds 3, 2 and 1 (each within the scatter of the next).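

In this assay, butyl on this oxygen reads level with (prop-1-en-1-yl)carbonyl (a 1.1-fold lower number from compound 2 to compound 3 (0.03 log units; within the scatter)), so replacing the acyl group with a saturated chain of similar size gives no step beyond the scatter. Lengthening the ether chain from propyl to butyl also stays within the scatter (a 1.5-fold lower number from compound 1 to compound 3 (0.16 log units; within the scatter)), and all three oxygen substituents shown now read level with one another. Nothing available here accounts for this flat reading.

Still open, on these data alone, is whether a different kind of group on this oxygen, such as an aminoethyl chain, a carboxylic acid or a much longer chain such as decyl, would give a step beyond the scatter. Also open, as far as these compounds go, is whether the level reading of these three compounds holds in any read-out other than this assay.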